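The source may hold more compounds than are shown below. What is called first, only, known or untested is meant among the compounds shown, and "the series" means these compounds.

Measured compounds:
compound 1 `Cc1ccccc1CCCCCCC(=O)N1CCCC1` — 68400 nM
compound 2 `Cc1ccc(CCCCCCC(=O)N2CCCC2)cc1` — 9600 nM
compound 3 `COc1cccc(CCCCCCC(=O)N2CCCC2)c1` — > 100000 nM

In an assay on HEK293 cells for inhibition of N-acylethanolamine-hydrolyzing acid amidase (Rattus norvegicus), read by LC-MS, with a stated time of 30 min (on this read-out lower numbers stand for stronger inhibition and higher numbers for weaker inhibition), compound 2 gives the lowest of the two numbers recorded, and compound 1 stands above it by a gap beyond the usual scatter. For compound 3 only a limit is reported, (the limit of > 100000 nM in this assay, at which 1 of the 3 values shown sits), so it contributes no number. Compound 4 `COc1ccc(CCCCCCC(=O)N2CCCC2)cc1` has not yet been measured in this assay. It differs from compound 2 by methoxy in place of methyl on an aromatic carbon. Within the data shown here, no measured pair shows this exact change, so the size of the step is uncertain; the nearest guide is compound 3, whose methoxy gives only a limit. Compound 4 is therefore expected to give 25000 nM in this assay, within 6000 nM to 100000 nM, a step of a 2.6-fold higher number from compound 2 to compound 4 (0.42 log units; beyond the scatter) that is expected to be a loss.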

Compound 4, half-maximal inhibitory concentration: 35400 nM
Estimate against measurement, compound 4: 1.4-fold (0.15 log units) below; the range from low to high includes it.
By their numbers in this assay, from the lowest: compound 2; then compounds 4 and 1 (each within the scatter of the next). At a limit, above all of these: compound 3.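

In this assay, methoxy in place of methyl on an aromatic carbon para to a large group gives a 3.7-fold higher number from compound 2 to compound 4 (0.57 log units; beyond the scatter), a modest loss. This puts a size on the change at this position, and the methoxy compound 4 still gives a number, 35400 nM. Compound 3 also carries methoxy, but its value is only a limit: the limit of > 100000 nM in this assay, at which 1 of the 4 values shown sits.

From the compounds shown here alone, whether a hydroxyl or a chlorine atom on this aromatic carbon would match methyl remains open. So does the outcome of a longer chain between the ring and the carbonyl.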